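The source may report more compounds than this note shows. Statements on the series, on what has been measured and on what is new or still open speak of the compounds shown alone.

Three analogues built on one shared core have been examined in a functional assay on BXPC-3 cells (Homo sapiens) for antiproliferative activity, read by sulforhodamine B assay, with a stated time of 72 h; on this read-out higher numbers stand for weaker inhibition and lower numbers for stronger inhibition. Compound 1 `CN(CCNCc1cn(-c2cccc(Cl)c2)nn1)CCNc1ccnc2cc(Cl)ccc12` gives 12000 nM. Compound 2 `CN(CCNCc1cn(Cc2ccc(Br)cc2)nn1)CCNc1ccnc2cc(Cl)ccc12` gives 8700 nM. Compound 3 `CN(CCNCc1cn(C(C)(C)C)nn1)CCNc1ccnc2cc(Cl)ccc12` gives 39000 nM, the highest of the three numbers; the steps of a 3.3-fold higher number from compound 1 to compound 3 (0.51 log units; beyond the scatter) and a 4.5-fold higher number from compound 2 to compound 3 (0.65 log units; beyond the scatter) both lie beyond the scatter, whereas a 1.4-fold lower number from compound 1 to compound 2 (0.14 log units; within the scatter) does not. Compound 4 `CN(CCNCc1cn(-c2ccnc3cc(Cl)ccc23)nn1)CCNc1ccnc2cc(Cl)ccc12` has not yet been measured in this assay. It differs from compound 3 by 7-chloroquinolin-4-yl in place of tert-butyl on an aromatic nitrogen. The measured steps that bear on this change are the two in which tert-butyl entered in place of an aromatic group on an aromatic nitrogen of the five-membered aromatic ring, namely a 3.3-fold higher number from compound 1 to compound 3 (0.51 log units; beyond the scatter) and a 4.5-fold higher number from compound 2 to compound 3 (0.65 log units; beyond the scatter), each a modest rise. The change from compound 3 to compound 4 again places an aromatic group on that nitrogen, so a lower number in this assay is expected, of a size comparable to those steps, and the expected step is a 3.9-fold lower number from compound 3 to compound 4 (0.59 log units; beyond the scatter). Compound 4 is accordingly estimated at 10000 nM in this assay, with a range from 4000 nM to 30000 nM.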

Compound 4, half-maximal inhibitory concentration: 8800 nM
For compound 4 the middle estimate is 1.1-fold (0.06 log units) above the measured one; measured number inside the range.
By their numbers in this assay, from the lowest: compounds 2, 4 and 1 (each within the scatter of the next); then compound 3.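

In this assay, 7-chloroquinolin-4-yl, with its two six-membered aromatic rings, lowers the number relative to tert-butyl (a 4.4-fold lower number from compound 3 to compound 4 (0.65 log units; beyond the scatter)), so the aromatic groups on this nitrogen of the five-membered ring are no longer limited to the single-ring groups of compound 1 and compound 2. Enlarging the group to two fused-on rings brings no separation from those groups (a 1.0-fold higher number from compound 2 to compound 4 (0.00 log units; within the scatter); a 1.4-fold lower number from compound 1 to compound 4 (0.13 log units; within the scatter)), so among these four compounds the three bearing an aromatic ring sit together and only compound 3, with tert-butyl, stands apart. No independent evidence bears on why the numbers fall this way.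

As far as these compounds go, it remains open whether a saturated ring such as cyclohexyl would behave like the aromatic groups or like tert-butyl. A longer alkyl chain, or a chain ending in an amine or a carboxylic acid, on this nitrogen also remains untested by the compounds shown.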